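A few compounds are considered here, and "the series" means these few. Any claim that something is new, unique, unknown or untested is made for them only; others in the source may bear on it.

Measured in a functional assay on CHO cells with adenosine receptor A1 (Homo sapiens) as the target, read by cAMP accumulation and immunoassay, with a stated time of 6 min, tested at 0.01 uM; a lower number here means a stronger effect, a higher number a weaker effect of the compound at the concentration tested:
compound 1 `Nc1scc(CN2CCN(c3ccc(Cl)cc3Cl)CC2)c1C(=O)c1ccc(Cl)cc1` gives 2%;
compound 2 `Nc1scc(CN2CCN(c3cccc(C(F)(F)F)c3)CC2)c1C(=O)c1ccc(Cl)cc1` gives -8.2%;
compound 3 `Nc1scc(CN2CCN(c3ccncc3)CC2)c1C(=O)c1ccc(Cl)cc1` gives -4%.

All three numbers sit near zero. Compound 2 stands apart from compound 1 by a number 10.2 percentage points lower from compound 1 to compound 2 (beyond the scatter), beyond the scatter, while its gap to compound 3, a number 4.2 percentage points higher from compound 2 to compound 3 (within the scatter), lies within it. The unmeasured compound 4 `Nc1scc(CN2CCN(c3cccc(F)c3F)CC2)c1C(=O)c1ccc(Cl)cc1` differs from compound 2 by 2,3-difluorophenyl in place of 3-(trifluoromethyl)phenyl on an amine nitrogen in a ring. The two steps that bear on it are the exchanges of the same ring on the same nitrogen, one modest and one within the scatter, and no change beyond the scatter is therefore expected in this assay for compound 4, with an expected step of a number 5.2 percentage points higher from compound 2 to compound 4 (within the scatter). Compound 4 is estimated at -3%, between -15% and 10%.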

Compound 4, a percentage reported as activity, at one concentration (the size of the read-out at that concentration, not a potency): -13%
Estimate against measurement, compound 4: 10 percentage points above, and the stated range covers the measured number.
By their numbers in this assay, from the lowest: compounds 4, 2, 3 and 1 (each within the scatter of the next, the first and the last beyond it).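

In this assay the exchange to 2,3-difluorophenyl on this amine nitrogen gives a number 4.8 percentage points lower from compound 2 to compound 4 (within the scatter) and a number 9 percentage points lower from compound 3 to compound 4 (within the scatter) so this ring adds no separation from either group. Only the exchange from 2,4-dichlorophenyl gives a larger change, with a number 15 percentage points lower from compound 1 to compound 4 (beyond the scatter) so both fluorine-bearing rings now stand apart from compound 1, while compound 3, whose step from compound 1 lies within the scatter, goes against this pattern. Still open, going by these compounds, is whether a methoxy group on the phenyl ring, or a carboxylic acid on it, would move the number beyond the scatter. No available evidence explains these differences.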